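A Thiophene Ring Takes the Place of a Butyl Chain

The source may hold more compounds than are shown below. What is called first, only, known or untested is meant among the compounds shown, and "the series" means these compounds.

Of the compounds shown here, three built on a shared core have been tested in a functional assay on MCF7 cells (Homo sapiens) for cytotoxicity, read by MTT assay, with a stated time of 24 h; a lower number here means a stronger inhibitor, a higher number a weaker inhibitor. Among the compounds with values here, compound 1 `O=C(NC(=S)Nc1nc2cc(Br)ccc2s1)c1ccccc1` gives 32100 nM, compound 3 `O=C(NC(=S)Nc1nc2cc([N+](=O)[O-])ccc2s1)c1ccccc1` gives 41600 nM, and the single step between them, a 1.3-fold higher number from compound 1 to compound 3 (0.11 log units; within the scatter), stays within the scatter. Compound 2 `CCCCC(=O)NC(=S)Nc1nc2cc(N)ccc2s1` gives 44700 nM; its number differs from those of compound 3 and compound 1 only by gaps within the scatter, so no ordering among the three can be read. Compound 4 `Nc1ccc2sc(NC(=S)NC(=O)c3cccs3)nc2c1` differs from compound 2 in one place: thiophen-2-yl in place of butyl on a carbonyl carbon. Within the data shown here, no measured step touches the carbonyl side of the core, so nothing known bears directly on this change, and compound 4 is expected to move little, the step of a 1.1-fold lower number from compound 2 to compound 4 (0.05 log units; within the scatter) lying within the scatter. Compound 4 is therefore estimated at 40000 nM, between 15000 nM and 100000 nM.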

Compound 4, half-maximal inhibitory concentration: 28400 nM
Beside the measured number, compound 4's estimate is 1.4-fold (0.15 log units) above it; low and high end bracket the measured number.
By their numbers in this assay, from the lowest: compounds 4, 1, 3 and 2 (each within the scatter of the next).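

Thiophen-2-yl in place of butyl is the first measured change on the carbonyl side of the shared core, and in this assay it gives a step within the scatter (a 1.6-fold lower number from compound 2 to compound 4 (0.20 log units; within the scatter)). This position therefore accepts a five-membered aromatic ring as well as a butyl chain, and this assay cannot tell the two apart. Nothing measured on these compounds offers an explanation for this result.

From the compounds shown here alone, whether a longer chain or a ring carrying a carboxylic acid on this carbonyl carbon would move the number beyond the scatter remains open.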